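The compounds below may be only part of what the source reports. "The series", "measured", "known", "first", "only" and "open" are said of these compounds alone.

Two compounds of this series have numbers in a functional assay on NCI-H2122 cells (Homo sapiens) for inhibition, read by microscopy, with a stated time of 10 days; on this read-out lower numbers stand for stronger inhibition and higher numbers for weaker inhibition. Compound 2 `N#CC1=C(N)Oc2c(c(-c3ccccc3)nn2-c2ccccc2)C1c1ccc(F)cc1` gives 4100 nM in this assay. Compound 1 `COc1ccc(-c2nn(-c3ccccc3)c3c2C(c2ccccc2)C(C#N)=C(N)O3)cc1` gives 7200 nM in this assay. The two numbers lie within the scatter of each other, so neither compound can be set apart from the other on what is shown; compound 2 simply holds one of the two values.

Compound 3 `COc1ccc(-c2nn(-c3ccccc3)c3c2C(c2ccc(F)cc2)C(C#N)=C(N)O3)cc1` is compound 2 with methoxy in place of hydrogen on an aromatic carbon. Going by the values given here, no measured pair differs by this change alone, so the size of the step is not known from measurement. Among the compounds with values here, the only guide is compound 1, which also carries the methoxy group and sits within the scatter of compound 2, which gives 4100 nM. For compound 3 the expected step is a 1.2-fold higher number from compound 2 to compound 3 (0.09 log units; within the scatter), not beyond the scatter. The estimate for compound 3 in this assay is 5000 nM, with an expected range from 2000 nM to 12000 nM.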

Compound 3, half-maximal inhibitory concentration: 6000 nM
Estimate against measurement, compound 3: 1.2-fold (0.08 log units) below, and the stated range covers the measured number.
By their numbers in this assay, from the lowest: compounds 2, 3 and 1 (each within the scatter of the next).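

Compound 3 gives the series its first measured pairs, so the size of each change can now be read rather than inferred. In this assay, methoxy in place of hydrogen, on the aromatic carbon para to a large group, gives a 1.5-fold higher number from compound 2 to compound 3 (0.17 log units; within the scatter), while fluoro in place of hydrogen on an aromatic carbon gives a 1.2-fold lower number from compound 1 to compound 3 (0.08 log units; within the scatter); neither change can therefore be told apart from no change in this read-out. No measurement available here bears on the origin of these numbers.

Still open, as far as these compounds go, is whether an amine, a carboxylic acid or a longer chain such as butoxy at the methoxy position would move the number beyond the scatter. Also open, from the compounds shown here alone, is whether the methoxy step would remain the same with a chloro group in place of the fluoro group.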